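Swapping the benzyl group on compound 1

The source may report more compounds than this note shows. Statements on the series, on what has been measured and on what is new or still open speak of the compounds shown alone.

Three measured compounds share the core of compound 1 `Nc1cc(N)c2nc(-c3ccccc3)c(NCc3ccc(Cl)c(Cl)c3)nc2c1` and vary only in the group carried on the amine. In a functional assay on SK-MEL-28 cells (Homo sapiens) for inhibition, read by sulforhodamine B assay, with a stated time of 48 h (a lower number here means a stronger inhibitor of growth, a higher number a weaker inhibitor of growth), compound 1 gives 41700 nM. Compound 2 `COc1cc(CNc2nc3cc(N)cc(N)c3nc2-c2ccccc2)cc(OC)c1OC` gives 17800 nM in this assay, and compound 3 `CCOC(=O)[C@H](CCC(=O)O)NC(=O)c1ccc(CNc2nc3cc(N)cc(N)c3nc2-c2ccccc2)cc1` gives 56200 nM. Compound 1 holds the second highest of the three numbers: its nearest neighbour is compound 3, whose value sits within the scatter of it, while compound 2 lies lower by a margin beyond the scatter. Among the compounds with values here, no pair of measured compounds differs in a single place, so no measured step guides the move to compound 4 `Nc1cc(N)c2nc(-c3ccccc3)c(NCc3ccc(F)cc3)nc2c1`. The change from compound 1 to compound 4 is 4-fluorophenyl in place of 3,4-dichlorophenyl on a saturated chain carbon bound to a nitrogen on an aromatic ring. Nothing measured here speaks to this exchange; the expectation is a move in this assay of no more than the scatter, with no fixed direction. The expected step is a 1.1-fold higher number from compound 1 to compound 4 (0.03 log units; within the scatter). Compound 4 is expected at 45000 nM, with a range from 18000 nM to 110000 nM.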

Compound 4, concentration for total growth inhibition: 3800 nM
The estimate for compound 4 lay 12-fold (1.07 log units) above the measured number; the measured number lies below the stated range.
By their numbers in this assay, from the lowest: compound 4; then compound 2; then compounds 1 and 3 (each within the scatter of the next).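

Working notes: the group on the saturated chain carbon bound to a nitrogen on an aromatic ring is a sensitive position in this assay. Within the data shown here, the exchange of 3,4-dichlorophenyl for 4-fluorophenyl gives an 11-fold lower number from compound 1 to compound 4 (1.04 log units; beyond the scatter), a large step beyond the scatter and the first single-place change that can be read. It shows that changing only the halogens on this phenyl ring, with the shared core held constant, can strongly alter growth inhibition. Nothing available here explains the size of this step.

Open, going by these compounds, is whether the step follows from losing the two chlorines, gaining the fluorine, or both; a plain phenyl group at this place would help separate these. Also open, on these data alone, is how an amine or a carboxylic acid on this phenyl ring would read in this assay.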